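The source may report more compounds than this note shows. Statements on the series, on what has been measured and on what is new or still open speak of the compounds shown alone.

Measured compounds:
compound 1, `CCN1C(=O)CN(C2CCCC2)c2nc(Nc3ccc(N4CCCCC4)cc3)ncc21`: 5470 nM
compound 2, `CCN1C(=O)CN(C2CCCC2)c2nc(Nc3ccc(N4CCC(C)CC4)cc3)ncc21`: 5400 nM
compound 3, `CCN1C(=O)CN(C2CCCC2)c2nc(Nc3ccc(N4CCCCC4)cn3)ncc21`: 14500 nM

All three were read in a functional assay on HCT-116 cells (Homo sapiens) for inhibition, read by MTT assay, with a stated time of 48 h; on this read-out lower numbers stand for stronger inhibition and higher numbers for weaker inhibition. Compound 1 and compound 2 differ only by methyl in place of hydrogen on a saturated ring carbon, and that change gave a 1.0-fold lower number from compound 1 to compound 2 (0.01 log units; within the scatter). Compound 3 carries a different core from compound 1; the difference between the two cores is not broken down here, and compound 3 stands at the highest number of the three. For the measured compounds named here, compound 4, `CCN1C(=O)CN(C2CCCC2)c2nc(Nc3ccc(N4CCC(C)CC4)cn3)ncc21`, is not yet measured; it differs from compound 3 by methyl in place of hydrogen on a saturated ring carbon, which is the same change as the one from compound 1 to compound 2. For compound 4 the expected step is a 1.0-fold lower number from compound 3 to compound 4 (0.02 log units; within the scatter), set close to zero because the earlier instance read a 1.0-fold lower number from compound 1 to compound 2 (0.01 log units; within the scatter). Compound 4 is therefore estimated at 14000 nM, with a likely range from 7000 nM to 28000 nM.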

Compound 4, half-maximal inhibitory concentration: 19100 nM
For compound 4 the middle estimate is 1.4-fold (0.13 log units) below the measured one; the range from low to high includes it.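

In this assay, the change from piperidin-1-yl to 4-methylpiperidin-1-yl gives a 1.3-fold higher number from compound 3 to compound 4 (0.12 log units; within the scatter), so on this second core, too, the step stays within the usual scatter. The two instances do not differ: the same change on two cores in this assay, a 1.0-fold lower number (0.01 log units; within the scatter) from compound 1 to compound 2 and a 1.3-fold higher number (0.12 log units; within the scatter) from compound 3 to compound 4, 1.3-fold (0.13 log units) apart, within the scatter of two such steps. Within these two pairs, the methyl can therefore be carried from one core to the other with little expected change in this read-out, but two pairs set no rule for other cores and say nothing about other assays.

Still open, as far as these compounds go, is whether a hydroxyl, an amine or a longer chain on the same saturated ring carbon would also leave the number unchanged. Also open, from the compounds shown here alone, is whether the methyl step holds on any further core.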